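The compounds below may be only part of what the source reports. "The series", "measured", "known", "first", "only" and "open" are said of these compounds alone.

Measured compounds: compound 1 `Nc1ccc(/C=C2\SC(=O)N(Cc3cccc(Cl)c3)C2=O)cc1` gives 18000 nM; compound 2 `Nc1cccc(/C=C2\SC(=O)N(Cc3cccc(F)c3)C2=O)c1` gives 250000 nM; compound 3 `Nc1ccc(/C=C2\SC(=O)N(Cc3ccc(F)cc3)C2=O)cc1` gives 111000 nM.

Within a functional assay on CCRF-CEM cells (Homo sapiens) for cytotoxicity, read by cell counting, with a stated time of 3 days (on this read-out lower numbers stand for stronger inhibition and higher numbers for weaker inhibition), compound 3 stands second highest of the three, with compound 2 beyond the scatter above it and compound 1 beyond the scatter below it. Compound 4 `Nc1ccc(/C=C2\SC(=O)N(Cc3cccc(F)c3)C2=O)cc1` differs from compound 3 by 3-fluorophenyl in place of 4-fluorophenyl on a saturated chain carbon bound to an amide-type nitrogen in a ring. Among the measured compounds shown here, only one measured step bears on this change: a 6.2-fold higher number from compound 1 to compound 3 (0.79 log units; beyond the scatter), which mixed a change of halogen with a change of its position, so it is only a partial guide. Compound 2 carries the same 3-fluorophenyl but a differently placed amine, so its value shows nothing directly. A modest lowering of the number is therefore expected, a 2.2-fold lower number from compound 3 to compound 4 (0.35 log units; beyond the scatter), giving an estimate for compound 4 of 50000 nM within a range of 15000 nM to 150000 nM.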

Compound 4, half-maximal inhibitory concentration: 116000 nM
Compound 4: middle estimate off by 2.3-fold (0.37 log units), on the low side; low and high end bracket the measured number.
By their numbers in this assay, from the lowest: compound 1; then compounds 3 and 4 (each within the scatter of the next); then compound 2.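

In this assay, 3-fluorophenyl in place of 4-fluorophenyl on the saturated chain carbon gives a step within the scatter (a 1.0-fold higher number from compound 3 to compound 4 (0.02 log units; within the scatter)), so the place of the fluorine does not separate compound 3 from compound 4. This isolates the halogen, since fluoro in place of chloro on an aromatic carbon gives a clear step (a 6.4-fold higher number from compound 1 to compound 4 (0.81 log units; beyond the scatter)), while 4-aminophenyl in place of 3-aminophenyl shows that the amine's place also counts (a 2.2-fold lower number from compound 2 to compound 4 (0.33 log units; beyond the scatter)). No measurement here offers an explanation for these steps.

Still open, going by these compounds, is whether 4-chlorophenyl would match the number of compound 1, and whether a bromo or methoxy group on that ring would give a lower number than chloro.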